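From 4-(trifluoromethyl)benzyl to 3-phenylpropyl on sulfur

The compounds below may be only part of what the source reports. "The series", "measured", "known", "first", "only" and "open" are said of these compounds alone.

In a toxicity assay on GES1 cells (Homo sapiens) for inhibition, read by MTT assay, with a stated time of 72 h (on this read-out higher numbers stand for weaker inhibition and lower numbers for stronger inhibition), compound 1 `Cc1cc(N2CC[C@@H](C)[C@@H](N(C)c3ncnc4[nH]ccc34)C2)n2nc(SCC3CC3)nc2n1` gives 27900 nM, compound 2 `Cc1cc(N2CC[C@@H](C)[C@@H](N(C)c3ncnc4[nH]ccc34)C2)n2nc(SCc3nc4ccccc4[nH]3)nc2n1` gives 40200 nM and compound 3 `Cc1cc(N2CC[C@@H](C)[C@@H](N(C)c3ncnc4[nH]ccc34)C2)n2nc(SCc3ccc(C(F)(F)F)cc3)nc2n1` gives 17300 nM. Compound 3 therefore stands level with compound 1 within the scatter, and lower than compound 2 alone. Compound 4 `Cc1cc(N2CC[C@@H](C)[C@@H](N(C)c3ncnc4[nH]ccc34)C2)n2nc(SCCCc3ccccc3)nc2n1` carries phenethyl in place of 4-(trifluoromethyl)phenyl on a saturated chain carbon bound to a sulfur. Three steps at this same place bear on it: a 1.4-fold higher number from compound 1 to compound 2 (0.16 log units; within the scatter), a 1.6-fold lower number from compound 1 to compound 3 (0.21 log units; within the scatter) and, modest, a 2.3-fold lower number from compound 2 to compound 3 (0.37 log units; beyond the scatter). No change beyond the scatter is therefore expected in this assay, and the estimated step is a 1.3-fold higher number from compound 3 to compound 4 (0.10 log units; within the scatter). Compound 4 is expected at 22000 nM, within an estimated range from 11000 nM to 45000 nM.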

Compound 4, half-maximal inhibitory concentration: > 100000 nM
Compound 4: only a limit was reported; the forecaster's own chance of this, stated with the estimate: 10%; middle value at least 4.5-fold (0.65 log units) from the limit.
By their numbers in this assay, from the lowest: compounds 3, 1 and 2 (each within the scatter of the next, the first and the last beyond it). At a limit, above all of these: compound 4.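

In this assay, replacing 4-(trifluoromethyl)benzyl with 3-phenylpropyl on sulfur gives an at least 5.7-fold higher number from compound 3 to compound 4 (0.76 log units; beyond the scatter), a wider step than any earlier one at this place. The other two compounds point the same way, with an at least 2.4-fold higher number from compound 2 to compound 4 (0.39 log units; beyond the scatter) and an at least 3.5-fold higher number from compound 1 to compound 4 (0.55 log units; beyond the scatter), so this position can shift the read-out well beyond the scatter. The result for compound 4 is a limit of the assay, not a number: the limit of > 100000 nM in this assay, at which 1 of the 4 values shown sits.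

This change both lengthens the chain and removes the trifluoromethyl group, and the compounds shown do not separate the two. A plain benzyl group, or a 3-phenylpropyl group carrying trifluoromethyl, would pull them apart.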